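A few compounds are considered here, and "the series" means these few. Any claim that something is new, unique, unknown or untested is made for them only; others in the source may bear on it.

Compound 1 `CCCn1ccc2cc(N3CCC(O)CC3)cc(Cl)c2c1=O` and compound 2 `CCCn1ccc2cc(N3CCNCC3)cc(Cl)c2c1=O` share one core and differ only in the group attached to an aromatic carbon of that core. In a functional assay on CHO cells for agonist activity at metabotropic glutamate receptor 2 (Homo sapiens), read by GTPgammaS binding (on this read-out higher numbers stand for larger maximal responses and lower numbers for smaller maximal responses), compound 1 gives 106%, while compound 2 gives 47%. Among the measured compounds shown here, this is a number 59 percentage points lower from compound 1 to compound 2 (beyond the scatter), so compound 2 stands at the lower of the two numbers so far, and its nearest neighbour in this assay is compound 1.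

Compound 3 `CCCn1ccc2cc(-c3ccncc3)cc(Cl)c2c1=O` carries a different group at the same place: pyridin-4-yl in place of piperazin-1-yl on an aromatic carbon. For the measured compounds named here, no measured pair follows this same exchange, so the only guidance is the single step seen at this position, a number 59 percentage points lower from compound 1 to compound 2 (beyond the scatter), which shows that changing the group here can move the maximal response far beyond the scatter in either direction. Because compound 2 sits at 47%, there is more room for an increase than for a further decrease, and an upward step in this assay of roughly a number 33 percentage points higher from compound 2 to compound 3 (beyond the scatter) is expected, with wide uncertainty. The maximal response of compound 3 in this assay is therefore estimated at 80%, in a range from 40% to 120%.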

Compound 3, largest response reached (Emax), in percent of the reference or control that the assay uses: 73%
Estimate against measurement, compound 3: 7 percentage points above; the range from low to high includes it.
By their numbers in this assay, from the lowest: compound 2; then compound 3; then compound 1.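

The step of a number 26 percentage points higher from compound 2 to compound 3 (beyond the scatter) shows that in this assay this place, on an aromatic carbon of the shared core, can carry an aromatic ring as well as a non-aromatic one, and that exchanging two rings with the same heavy-atom count can still shift the maximal response beyond the scatter. The other comparison, a number 33 percentage points lower from compound 1 to compound 3 (beyond the scatter), places pyridin-4-yl between the two non-aromatic groups, so 4-hydroxypiperidin-1-yl still gives the largest response of the three, and the outcome depends on which ring is attached rather than simply on whether that ring is aromatic. Nothing available explains why these three groups give different maximal responses.

The compounds shown leave open whether the nitrogen of pyridin-4-yl matters, and whether its location in the ring does, which a phenyl ring and pyridin-3-yl would help to test. They also do not separate the contribution of the hydroxyl in 4-hydroxypiperidin-1-yl from that of its ring, a question that plain piperidin-1-yl or morpholin-4-yl could address.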